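Methoxy added to the phenyl of compound 3

The compounds below may be only part of what the source reports. "The series", "measured", "known", "first", "only" and "open" are said of these compounds alone.

Measured so far:
compound 1 `CN1CCN(c2ccc(-c3cc4[nH]nc(N)c4c(=O)[nH]3)cc2)CC1` — 6%
compound 2 `COCCNc1nc(C)cc2c1c(N)nn2C` — -3%
compound 3 `Nc1c2c(=O)[nH]c(-c3ccccc3)cc2nn1-c1ccccc1` — -1%

In an assay on isolated protein for inhibition of RAC-beta serine/threonine-protein kinase (Homo sapiens), read by mobility shift assay, tested at 30 uM (a higher number here means more inhibition at the concentration tested (going by the name of the read-out), a lower number less inhibition), compound 1 gives 6%, compound 2 gives -3% and compound 3 gives -1%. All three numbers lie within the usual scatter of one another, so none of the compounds separates from the rest; compound 3 sits in the same band as compound 1 and compound 2, close to zero inhibition.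

Compound 4 `COc1ccc(-c2cc3nn(-c4ccccc4)c(N)c3c(=O)[nH]2)cc1` is the next one for this assay. It differs from compound 3 in a single place:

methoxy in place of hydrogen on an aromatic carbon

Cut one bond further out, this reads phenyl to 4-methoxyphenyl. Going by the values given here, with no measured step on which to rest and every value so far near zero, the step of a number 4 percentage points higher from compound 3 to compound 4 (within the scatter) is expected to stay within the scatter, in no clear direction. Compound 4 is therefore estimated at 3%, between -10% and 18%.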

Compound 4, a percentage reported as inhibition, at one concentration (the size of the read-out at that concentration, not a potency): 0%
For compound 4 the middle estimate is 3 percentage points above the measured one, and the stated range covers the measured number.
By their numbers in this assay, from the lowest: compounds 2, 3, 4 and 1 (each within the scatter of the next).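

In this assay, going by these compounds alone, the first single-place comparison reads a number 1 percentage points higher from compound 3 to compound 4 (within the scatter), so methoxy in place of hydrogen on this aromatic carbon, para to a large group, does not separate from the parent. Phenyl and 4-methoxyphenyl both stay near zero inhibition at this position. No measurement at hand bears on the reason for this result.

Open, going by these compounds, is whether an amine, a hydroxyl or a carboxylic acid in the same place would give a number clear of the scatter. Also open, on these data alone, is whether any single change on the shared core would do so.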